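The source may hold more compounds than are shown below. What is called first, only, known or untested is meant among the compounds shown, and "the series" means these compounds.

Among the measured compounds shown here, in a functional assay on A549 cells (Homo sapiens) for cytotoxicity, read by MTT assay, with a stated time of 72 h (a higher number here means a weaker inhibitor, a lower number a stronger inhibitor), compound 1 `CN(C)Cc1ccc2nc(NC(=O)N/N=C/c3cn(Cc4ccccc4)c4ccccc34)sc2c1` gives 2900 nM, and compound 2 `CN(C)Cc1ccc2nc(NC(=O)N/N=C/c3cn(Cc4cccc(Cl)c4)c4ccccc34)sc2c1` gives 1240 nM, the lower of the two numbers so far. Compound 3 `CN(C)Cc1ccc2nc(NC(=O)N/N=C/c3cn(Cc4ccc(Cl)c(Cl)c4)c4ccccc34)sc2c1` differs from compound 2 by one substitution: chloro in place of hydrogen on an aromatic carbon, taking 3-chlorobenzyl to 3,4-dichlorobenzyl. For the measured compounds named here, only one measured step bears on this, the same kind of replacement at another ring carbon, and it is modest: a 2.3-fold lower number from compound 1 to compound 2 (0.37 log units; beyond the scatter). A single step is thin support, so a further modest move toward a lower number is expected, and it may stay close to the scatter. The estimated change is a 1.7-fold lower number from compound 2 to compound 3 (0.22 log units; within the scatter). Compound 3 is expected at 750 nM, with an estimated range from 300 nM to 1900 nM.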

Compound 3, half-maximal inhibitory concentration: 940 nM
Estimate against measurement, compound 3: 1.3-fold (0.10 log units) below; the range from low to high includes it.
By their numbers in this assay, from the lowest: compounds 3 and 2 (each within the scatter of the next); then compound 1.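

In this assay, the second chloro, on the ring carbon para to a large group and ortho to a chloro group, gives a 1.3-fold lower number from compound 2 to compound 3 (0.12 log units; within the scatter), so this position adds nothing distinguishable once 3-chlorobenzyl is present. Measured against phenyl, 3,4-dichlorophenyl gives a 3.1-fold lower number from compound 1 to compound 3 (0.49 log units; beyond the scatter), so the change beyond the scatter holds with both chloro groups on the ring. No measured evidence accounts for this result.

Open, as far as these compounds go, is how methoxy, an amine or a carboxylic acid would read at this ring carbon. Also open, from the compounds shown here alone, is the effect of a longer chain between this ring and the aromatic nitrogen.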